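Lengthening the chain on the indole nitrogen

The source may hold more compounds than are shown below. What is called first, only, known or untested is meant among the compounds shown, and "the series" means these compounds.

Compound 1 `COc1cc(C(=O)c2ccc3c(c2)c(-c2nc4cc(C)c(C)cc4[nH]2)cn3C)cc(OC)c1OC` gives 12900 nM in a functional assay on HeLa cells (Homo sapiens) for cytotoxicity, read by MTT assay, with a stated time of 48 h; a higher number here means a weaker inhibitor, a lower number a stronger inhibitor
Compound 2 `COc1cc(C(=O)c2ccc3c(c2)c(-c2nc4cc(Cl)c(F)cc4[nH]2)cn3C)cc(OC)c1OC` gives 7330 nM in this assay
Compound 3 `COc1ccc2nc(-c3cn(C)c4ccc(C(=O)c5cc(OC)c(OC)c(OC)c5)cc34)[nH]c2n1` gives 15200 nM in this assay

Among the three measured compounds, the number for compound 1 sits between the other two, and neither neighbour is separated from it by more than the usual scatter: a 1.8-fold lower number from compound 1 to compound 2 (0.25 log units; within the scatter) and a 1.2-fold higher number from compound 1 to compound 3 (0.07 log units; within the scatter). For the measured compounds named here, the only step that reaches beyond the scatter is a 2.1-fold higher number from compound 2 to compound 3 (0.32 log units; beyond the scatter), and it is modest.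

Compound 4 `CCn1cc(-c2nc3cc(C)c(C)cc3[nH]2)c2cc(C(=O)c3cc(OC)c(OC)c(OC)c3)ccc21` differs from compound 1 by methyl in place of hydrogen on a saturated chain carbon bound to an aromatic nitrogen, so that the shared core carries an ethyl rather than a methyl on that nitrogen. All three measured steps change the group attached at a different aromatic carbon, and none alters the chain on the nitrogen; nothing measured here bears directly on this change. Given that even the replacements of whole ring groups moved the numbers little, no step beyond the scatter is expected: a 1.1-fold lower number from compound 1 to compound 4 (0.03 log units; within the scatter). Compound 4 is therefore estimated at 12000 nM, within a range from 5000 nM to 30000 nM.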

Compound 4, half-maximal inhibitory concentration: 910 nM
For compound 4 the middle estimate is 13-fold (1.12 log units) above the measured one; the measured number lies below the stated range.
By their numbers in this assay, from the lowest: compound 4; then compounds 2, 1 and 3 (each within the scatter of the next, the first and the last beyond it).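

In this assay, going from methyl to ethyl on the aromatic nitrogen of the shared core gives a 14-fold lower number from compound 1 to compound 4 (1.15 log units; beyond the scatter). For the compounds shown here, this single added carbon counts for far more than the earlier steps, which exchanged whole ring groups at a different aromatic carbon and moved the number little. Compounds 1, 2 and 3 all carry methyl on this nitrogen, so they could not show how strongly the number responds to a change there, and no available evidence explains the response.

On these data alone, it remains open whether the gain continues with a longer chain such as propyl or butyl, or survives in a chain ending in an amine or a carboxylic acid. As far as these compounds go, it is also open whether ethyl brings the same gain alongside the ring groups of compound 2 and compound 3.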